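The source may hold more compounds than are shown below. What is called first, only, known or untested is meant among the compounds shown, and "the series" means these compounds.

Measured compounds:
compound 1 `CCN(CC)c1ccc2cc(C(=O)c3ccc(N4CCN(C(=O)CN5CCN(C(=O)CCl)CC5)CC4)cc3)oc2c1`, 3060 nM
compound 2 `CCN(CC)c1ccc2cc(C(=O)c3ccc(N4CCN(C(=O)CN5CCN(S(=O)(=O)c6ccc(F)cc6)CC5)CC4)cc3)oc2c1`, 33200 nM
compound 3 `C#CCN1CCN(CC(=O)N2CCN(c3ccc(C(=O)c4cc5ccc(N(CC)CC)cc5o4)cc3)CC2)CC1`, a limit only, > 40000 nM

All three share one core and differ only in the group on an amine nitrogen in a ring. In a functional assay on A549 cells (Homo sapiens) for cytotoxicity, read by MTT assay, with a stated time of 48 h (on this read-out lower numbers stand for stronger inhibition and higher numbers for weaker inhibition), compound 1 gives 3060 nM. Compound 2 reaches 33200 nM, which is an 11-fold higher number from compound 1 to compound 2 (1.04 log units; beyond the scatter). For compound 3 this assay reports only a limit, > 40000 nM. That is an at least 13-fold higher number from compound 1 to compound 3 (1.11 log units; beyond the scatter), whereas an at least 1.2-fold higher number from compound 2 to compound 3 (0.08 log units; that floor lies within the scatter). Compound 3 thus sits at the limit of > 40000 nM in this assay, at which 1 of the 3 values shown sits.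

Compound 4 `CCN(CC)c1ccc2cc(C(=O)c3ccc(N4CCN(C(=O)CN5CCN(Cc6ccc(/C=C/C(=O)OC)cc6)CC5)CC4)cc3)oc2c1` carries a further change: 4-(2-(methoxycarbonyl)ethenyl)phenyl in place of ethynyl on a saturated chain carbon bound to an amine nitrogen in a ring. Going by the values given here, no measured step touches this part of the structure, so the expectation rests on compound 3 alone. The step from compound 3 is expected to be a number no higher from compound 3 to compound 4 (the limit leaves the size open), with wide uncertainty. Compound 4 is therefore estimated at 40000 nM, between 8000 nM and 100000 nM.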

Compound 4, half-maximal inhibitory concentration: 2810 nM
Estimate against measurement, compound 4: 14-fold (1.15 log units) above; the whole stated range lies above it.
By their numbers in this assay, from the lowest: compounds 4 and 1 (each within the scatter of the next); then compound 2. At a limit, above all of these: compound 3.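

On a saturated chain carbon bound to an amine nitrogen in a ring, 4-(2-(methoxycarbonyl)ethenyl)phenyl in place of ethynyl gives an at least 14-fold lower number from compound 3 to compound 4 (1.15 log units; beyond the scatter). Compound 3 has a limit rather than a number, so this step gives only a floor because of that limit: the limit of > 40000 nM in this assay, at which 1 of the 4 values shown sits. Until now only compound 1, with its (chloromethyl)carbonyl group, had a low number, but compound 4 at 2810 nM lies within the scatter of compound 1 at 3060 nM, without that group.

Still open, going by these compounds, is which part of the entering group matters: the aromatic ring, the double bond or the methyl ester. A plain benzyl group, or a carboxylic acid in place of the ester, could separate these.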